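Reshuffling the same atoms at the aryl ether oxygen

This account rests on a few compounds, and the source may have more. Where it says the series, first, only, none or still open, it means among the compounds named here.

Measured so far:
compound 1, `CCO/N=C/c1c(N)ncnc1Oc1ccc(NC(=O)C2(C(=O)Nc3ccc(F)cc3)CC2)cc1F`, 3.41
compound 2, `Nc1ncnc(Oc2ccc(NC(=O)C3(C(=O)Nc4ccc(F)cc4)CC3)cc2F)c1/C=N/OCc1ccccc1`, 4.45
compound 3, `Nc1ncnc(Oc2ccc(NC(=O)C3(C(=O)Nc4ccc(F)cc4)CC3)cc2F)c1/C=N/OC1CCCCC1`, 4.69

All three were tested in a physicochemical assay for lipophilicity, using the shake flask method; a lower number here means a more polar compound, a higher number a more lipophilic compound. Compound 1 stands lowest of the three. Compound 2 lies a number 1.04 log units higher from compound 1 to compound 2 (beyond the scatter), and compound 3 lies a number 1.28 log units higher from compound 1 to compound 3 (beyond the scatter); between compound 2 and compound 3 the gap is a number 0.24 log units higher from compound 2 to compound 3 (within the scatter). Both large steps come from putting a bulkier group on the oxygen of the oxime ether of compound 1, either phenyl on the saturated chain carbon or cyclohexyl in place of ethyl.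

Compound 4, `CNc1ncnc(Oc2ccc(NC(=O)C3(C(=O)Nc4ccc(F)cc4)CC3)cc2F)c1/C=N/OC`, has not been measured. It differs from compound 1 by a group of 12 heavy atoms (7 carbon, 4 nitrogen, 1 oxygen; one six-membered aromatic ring with 2 hetero atoms) in place of a group of 12 heavy atoms (7 carbon, 4 nitrogen, 1 oxygen; one six-membered aromatic ring with 2 hetero atoms), on an oxygen on an aromatic ring; the two have the same atoms, joined differently. The group on the oxime oxygen becomes shorter, while the amine on the shared core carries a methyl instead. Among the compounds with values here, no measured step follows this kind of rearrangement. The steps from compound 1 to compound 2 and to compound 3 show that enlarging the group on the oxime oxygen raises the number, so shortening it should pull the other way, while the methyl on the amine is expected to offset part of that. The step from compound 1 to compound 4 in this assay is therefore expected to be a number 0.11 log units lower from compound 1 to compound 4 (within the scatter). Compound 4 is estimated at 3.3, within 2.8 to 3.8.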

Compound 4, partition coefficient: 3.52
Compound 4: the middle estimate sits 0.22 log units below what was measured, within the range that was stated.
By their numbers in this assay, from the lowest: compounds 1 and 4 (each within the scatter of the next); then compounds 2 and 3 (each within the scatter of the next).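

In this assay, within the data shown here, the first swap that keeps the atoms the same but joins them differently, on an oxygen on an aromatic ring, gives a step that cannot be told apart from no difference: a number 0.11 log units higher from compound 1 to compound 4 (within the scatter). This contrasts with the large step seen when a larger group is added at the oxime oxygen, a number 1.04 log units higher from compound 1 to compound 2 (beyond the scatter), and shows that a methyl on the amine together with a shorter group on the oxime oxygen can leave compound 4 level with compound 1, at least in this single pair. Nothing measured here accounts for how the two changes come out so close to each other.

Going by these compounds, the two changes arrive together in compound 4, so the share of each one remains unknown, and the level result may hide two opposite shifts or two very small ones. How a dimethylamino group in place of the amine, or a hydroxyethyl group on the oxime oxygen, would read in this assay stays open in the compounds shown.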